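Reshaping the Amine-Bearing Chain on a Shared Core

The source may report more compounds than this note shows. Statements on the series, on what has been measured and on what is new or still open speak of the compounds shown alone.

Three measured compounds share one core and differ only in the chain that carries a free amine on the central tertiary nitrogen. Compound 1 `CC(C)(CCN)CN(C[C@H]1Cc2ccccc2CN1)[C@H]1CCCc2cccnc21` was tested in a functional assay on cells for antagonist activity at C-X-C chemokine receptor type 4 (Homo sapiens), read by fluorescence and calcium flux, with stated times of 25 min and 90 s; a higher number here means a weaker inhibitor, a lower number a stronger inhibitor. For compound 1 the result is a limit of the assay, > 33300 nM (the limit of > 33300 nM in this assay, at which 1 of the 3 values shown sits). Compound 2 `CC(C)(CN)CCN(C[C@H]1Cc2ccccc2CN1)[C@H]1CCCc2cccnc21` gives 69 nM in this assay, and compound 3 `CC(C)(N)CCCN(C[C@H]1Cc2ccccc2CN1)[C@H]1CCCc2cccnc21` gives 24.6 nM. The steps are an at least 480-fold lower number from compound 1 to compound 2 (2.68 log units; beyond the scatter) and an at least 1300-fold lower number from compound 1 to compound 3 (3.13 log units; beyond the scatter), both large, and a 2.8-fold lower number from compound 2 to compound 3 (0.45 log units; beyond the scatter), a more modest one. Among the two numbers shown, compound 3 holds the lowest, with compound 2 nearest.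

Compound 4 `C(=C/CN(C[C@H]1Cc2ccccc2CN1)[C@H]1CCCc2cccnc21)\CNC1CCOCC1` has not yet been measured. Its change from compound 3 is 3-((oxan-4-yl)amino)prop-1-en-1-yl in place of 3-amino-3-methylbutyl on a saturated chain carbon bound to an amine nitrogen. Going by the values given here, the measured steps show that the arrangement of the amine-bearing chain can shift the readout in this assay by a great deal, yet every potent compound so far kept an amine on that chain, and compound 4 does too, though in a larger and differently built chain. A change of modest size in either direction is therefore expected, with some risk of a larger loss. Compound 4 is estimated at 35 nM, with a likely range from 8 nM to 150 nM, which is an expected step of a 1.4-fold higher number from compound 3 to compound 4 (0.15 log units; within the scatter).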

Compound 4, half-maximal inhibitory concentration: 15.5 nM
Compound 4: the middle estimate sits 2.3-fold (0.35 log units) above what was measured, and the stated range covers the measured number.
By their numbers in this assay, from the lowest: compounds 4 and 3 (each within the scatter of the next); then compound 2. At a limit, above all of these: compound 1.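

The step of a 1.6-fold lower number from compound 3 to compound 4 (0.20 log units; within the scatter) in this assay shows that this place, on a saturated chain carbon bound to an amine nitrogen, can carry far more than a short branched amine chain: 3-((oxan-4-yl)amino)prop-1-en-1-yl brings a six-membered non-aromatic ring and a double bond, and the readout stays within the scatter of that for 3-amino-3-methylbutyl. The same group also gives a 4.5-fold lower number from compound 2 to compound 4 (0.65 log units; beyond the scatter), a modest change, so the chain need not be a small branched one to beat compound 2 in this assay. The step of an at least 2100-fold lower number from compound 1 to compound 4 (3.33 log units; beyond the scatter) starts from a limit of the assay for compound 1, not from a number: the limit of > 33300 nM in this assay, at which 1 of the 4 values shown sits.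

The compounds shown leave open how much of this result belongs to the double bond and how much to the oxan-4-yl ring, as the two enter together; a saturated propyl chain carrying the same ring, or a cyclohexyl ring in place of the oxane ring, would separate them. They also leave open whether the chain needs its amine at all, which a chain ending in a hydroxyl group would test.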